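Swapping a Propyl Ester for an Acetoxymethyl Group

The source may report more compounds than this note shows. Statements on the series, on what has been measured and on what is new or still open speak of the compounds shown alone.

Three compounds built on the shared core were tested in a functional assay on RAW264.7 cells (Mus musculus), read by fluorescence; a lower number here means a stronger inhibitor, a higher number a weaker inhibitor. Compound 1 `CCOC(=O)C1=CCCCC1NS(=O)(=O)c1ccc(F)cc1Cl` gives only > 10000 nM in this assay; that figure is a limit of the assay rather than a number, as recorded under (the limit of > 10000 nM in this assay, at which 1 of the 3 values shown sits). Compound 2 `CCOC(=O)C1=CCCCC1S(=O)(=O)Cc1ccsc1` gives 105 nM in this assay. Compound 3 `CCCOC(=O)C1=CCCCC1S(=O)(=O)Cc1ccc(F)cc1Cl` gives 14 nM in this assay, the lowest of the two numbers, and its gap to compound 2 lies beyond the usual scatter.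

Compound 4 `CC(=O)OCC1=CCCCC1S(=O)(=O)Cc1ccc(F)cc1Cl` has not yet been measured. It differs from compound 3 in one place: acetoxymethyl in place of propoxycarbonyl on a double-bonded ring carbon. Among the measured compounds shown here, no measured pair shows this change, so the expectation rests on compound 3 alone. A modest weakening is expected, the estimated step being a 3.2-fold higher number from compound 3 to compound 4 (0.51 log units; beyond the scatter). Compound 4 is therefore estimated at 45 nM in this assay, with a likely range from 10 nM to 300 nM.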

Compound 4, half-maximal inhibitory concentration: > 10000 nM
Compound 4: a limit, no number; the forecaster's own chance of this, stated with the estimate: 5%; at least 220-fold (2.34 log units) between middle value and limit.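

In this assay, exchanging propoxycarbonyl for acetoxymethyl on a double-bonded ring carbon gives an at least 710-fold higher number from compound 3 to compound 4 (2.85 log units; beyond the scatter), so the group at this position can decide whether the compound shows measurable inhibition here. The change looks small on paper: the two groups have the same counts of hydrogen-bond donors and acceptors, and neither carries a net charge, so these counts do not separate a strong inhibitor from a compound with no number. The result for compound 4 is a limit of the assay and not a number: the limit of > 10000 nM in this assay, at which 2 of the 4 values shown sit.

From the compounds shown here alone, the full size of this step remains open. Also open, going by these compounds, is how a carboxylic acid, a hydroxymethyl group, an amide or a butyl ester would behave on this ring carbon, and which of them, if any, would keep inhibition near that of compound 3.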